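The source may report more compounds than this note shows. Statements on the series, on what has been measured and on what is new or still open speak of the compounds shown alone.

Measured so far:
- compound 1, `CCCCCCCC/C=C\CCCCCCCCNC(=O)Nc1c(Cl)cc(Cl)cc1Cl`: 1200 nM
- compound 2, `CCCCCCCC/C=C\CCCCCCCCNC(=O)Nc1ccccc1CC`: 980 nM
- compound 3, `CCCCCCCC/C=C\CCCCCCCCNC(=O)Nc1c(C)cccc1Cl`: 180 nM

Of these three, compound 3 stands lowest in an assay on microsomes from intestinal mucosa for inhibition of acyl-CoA:cholesterol acyltransferase (Oryctolagus cuniculus); a lower number here means a stronger inhibitor, a higher number a weaker inhibitor; its nearest neighbour is compound 2, the furthest is compound 1, and both gaps are beyond the scatter, so compound 3 is the strongest inhibitor here. The new compound 4, `CCCCCCCC/C=C\CCCCCCCCNC(=O)Nc1c(CC)cccc1C(C)C`, keeps the long unsaturated chain and the urea link of the shared core and changes only the aryl group: 2-ethyl-6-isopropylphenyl in place of 2-chloro-6-methylphenyl on an amide-type nitrogen.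

Among the measured compounds shown here, two measured steps bear on this. From a single ethyl group on the ring to a chloro plus a methyl group the number fell, a 5.4-fold lower number from compound 2 to compound 3 (0.74 log units; beyond the scatter); from three chlorines to chloro plus methyl it fell as well, a 6.7-fold lower number from compound 1 to compound 3 (0.82 log units; beyond the scatter). For the measured compounds named here, compound 4 keeps two groups flanking the nitrogen, as compound 3 does, but replaces the chlorine with a larger alkyl group, a change no measured pair covers directly. The expectation for this assay is therefore a step of at most modest size, if any, most likely towards a somewhat higher number, a 1.4-fold higher number from compound 3 to compound 4 (0.16 log units; within the scatter). Compound 4 is estimated at 260 nM, with a range from 80 nM to 850 nM.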

Compound 4, half-maximal inhibitory concentration: 37 nM
For compound 4 the middle estimate is 7.0-fold (0.85 log units) above the measured one; the whole stated range lies above it.
By their numbers in this assay, from the lowest: compound 4; then compound 3; then compounds 2 and 1 (each within the scatter of the next).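

Putting 2-ethyl-6-isopropylphenyl in place of 2-chloro-6-methylphenyl on the amide-type nitrogen gives a 4.9-fold lower number from compound 3 to compound 4 (0.69 log units; beyond the scatter) in this assay, so among these compounds the lowest number belongs to an aryl group with no chlorine and with two alkyl groups. Isopropyl in place of hydrogen on an aromatic carbon gives a 26-fold lower number from compound 2 to compound 4 (1.42 log units; beyond the scatter) in the same assay, and the change from 2,4,6-trichlorophenyl gives a 32-fold lower number from compound 1 to compound 4 (1.51 log units; beyond the scatter) as the largest step here. No measurement at hand explains these gains.

Going by these compounds, the two alkyl groups of compound 4 entered together relative to compound 3, so their separate shares remain unknown. On these data alone, it also remains open whether a tert-butyl group, a methoxy group or an amine on this ring would lower the number further.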